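The source may report more compounds than this note shows. Statements on the series, on what has been measured and on what is new or still open speak of the compounds shown alone.

Of the compounds shown here, three sharing one core have been tested in a functional assay on MKN-74 cells (Homo sapiens) for antiproliferative activity, with a stated time of 24 h; on this read-out higher numbers stand for weaker inhibition and lower numbers for stronger inhibition. Compound 1 `NC(=O)c1c(NC(=O)c2ccccc2Cl)sc2c1CCNC2` gives 28700 nM. Compound 2 `NC(=O)c1c(NC(=O)c2cccc([N+](=O)[O-])c2)sc2c1CCN(Cc1c(Cl)cccc1Cl)C2`, which carries a nitro-bearing ring on the amide and a chlorinated benzyl group on the ring nitrogen, gives 13500 nM. Compound 3 `NC(=O)c1c(NC(=O)c2ccccc2Br)sc2c1CCN(C(=S)Nc1ccccc1Cl)C2`, which carries a thiourea-linked chlorophenyl group on the ring nitrogen, gives 12900 nM.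

Among these three numbers compound 3 stands lowest, but its gap to compound 2 is within the scatter of the measurement, so the two cannot be told apart; only the gap to compound 1 lies beyond the scatter, with compound 1 giving the higher number.

Compound 4 `NC(=O)c1c(NC(=O)c2ccncn2)sc2c1CCN(C(=S)Nc1ccccc1Cl)C2` has not yet been measured in this assay. It differs from compound 3 in one place: pyrimidin-4-yl in place of 2-bromophenyl on a carbonyl carbon. Going by the values given here, no measured pair shows this exact change, so its effect can only be guessed from how little the three known numbers move across rather different substitutions.

The step is expected to be small, leaning toward a somewhat higher number, and possibly none beyond the scatter: a 1.6-fold higher number from compound 3 to compound 4 (0.19 log units; within the scatter). For compound 4 the expected value is 20000 nM, with a likely range from 6000 nM to 60000 nM.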

Compound 4, half-maximal inhibitory concentration: 28400 nM
For compound 4 the middle estimate is 1.4-fold (0.15 log units) below the measured one, within the range that was stated.
By their numbers in this assay, from the lowest: compounds 3 and 2 (each within the scatter of the next); then compounds 4 and 1 (each within the scatter of the next).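

Going by these compounds alone, this is the first pair in this assay that differs in one place, so the group on the carbonyl carbon can be judged on its own while the rest of the molecule stays fixed. Replacing 2-bromophenyl with pyrimidin-4-yl gives a 2.2-fold higher number from compound 3 to compound 4 (0.34 log units; beyond the scatter), which shows that this position responds to the group it carries and that, in this one pair, the ring with 2 hetero atoms and hydrogen-bond acceptors goes with weaker inhibition than the carbon-only ring bearing bromine. No measurement at hand says what lies behind this step.

This single swap changes the ring atoms and removes the bromine together, so it cannot separate those two changes; plain phenyl and pyridin-4-yl on the same carbonyl carbon would help pull them apart. It also leaves open whether the step would stay the same with a different group on the ring nitrogen, and how a non-aromatic group such as cyclohexyl would behave at this position.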